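The compounds below may be only part of what the source reports. "The series", "measured", "known", "first", "only" and "open" are said of these compounds alone.

Working notes on the series. In an assay on isolated protein for inhibition of Amine oxidase [flavin-containing] A (Rattus norvegicus) (a lower number here means a stronger inhibitor, a higher number a weaker inhibitor), compound 1 `CC(C)NCc1cn(Cc2ccccc2)c2ccccc12` gives 133000 nM, the highest of the three numbers recorded. The nearest is compound 3 `CC#CCNCc1cc2cc(OCc3ccccc3)ccc2[nH]1`, which in this assay gives 5250 nM; compound 2 `CC#CCN(C)Cc1cc2ccccc2n1C` lies furthest away and in this assay gives 4.3 nM. Both of those gaps sit well beyond the scatter, so compound 1 is the weakest of the measured set.

Compound 4 `C#CCN(C)Cc1cn(Cc2ccccc2)c2ccccc12` has not been measured. Against compound 1 it differs in one place: methyl(propargyl)amino in place of isopropylamino on a saturated chain carbon bound to an aromatic carbon. The core of compound 1 is kept, and what changes is the amine on the saturated chain carbon bound to an aromatic carbon.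

For the measured compounds named here, no measured pair shows this exact change. Still, the two compounds that carry a chain with a triple bond outside aromatic rings, compound 2 at 4.3 nM and compound 3 at 5250 nM, both give far lower numbers than compound 1. The step from compound 1 to compound 4 is therefore expected to be large and downward, a 170-fold lower number from compound 1 to compound 4 (2.22 log units; beyond the scatter). Compound 4 is expected to give about 800 nM, with a plausible range from 80 nM to 8000 nM.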

Compound 4, inhibition constant: 160000 nM
Compound 4: the middle estimate sits 200-fold (2.30 log units) below what was measured; measured number above the stated range.
By their numbers in this assay, from the lowest: compound 2; then compound 3; then compounds 1 and 4 (each within the scatter of the next).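

In this assay, methyl(propargyl)amino in place of isopropylamino on a saturated chain carbon bound to an aromatic carbon gives a 1.2-fold higher number from compound 1 to compound 4 (0.08 log units; within the scatter), so on the core of compound 1 this swap of amine leaves the number unchanged within the scatter. The triple bond outside aromatic rings, together with the loss of the hydrogen-bond donor, therefore does not by itself bring a lower number on this core. Nothing available accounts for this flat step.

From the compounds shown here alone, it remains open whether a plain propargylamino group, a dimethylamino group or a longer chain carrying the triple bond would give a different number at this place on the core of compound 1. The compounds shown hold no pair with the same amine change on another core, so whether this flat step holds elsewhere cannot be read.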